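A formyl group in place of methyl on compound 2

The source may hold more compounds than are shown below. What is called first, only, known or untested is meant among the compounds shown, and "the series" means these compounds.

In a functional assay on A2780 cells (Homo sapiens) for inhibition (on this read-out higher numbers stand for weaker inhibition and lower numbers for stronger inhibition), compound 2 `Cc1ccc(-c2cc(C)oc(=O)c2)cc1` gives > 50000 nM, which is a limit of the assay and not a number. Compound 1 `Cc1cc(-c2ccc(Cl)cc2)cc(=O)o1` gives > 50000 nM in this assay, again a limit. Compound 3 `C#Cc1cc(C)oc(=O)c1` gives 3100 nM in this assay. Within the data shown here, the only measured step, a step that the two limits leave unreadable from compound 1 to compound 2, cannot be read because both of its values sit at the limit of > 50000 nM in this assay, at which 2 of the 3 values shown sit. Compound 4 `Cc1cc(-c2ccc(C=O)cc2)cc(=O)o1` differs from compound 2 by formyl in place of methyl on an aromatic carbon. Among the measured compounds shown here, no measured step bears on this change, so neither a size nor a direction can be drawn from the measured pairs. Compound 4 is therefore expected to stay near the limit, with an estimated 45000 nM (range 10000 nM to 200000 nM). The expected step is an at least 1.1-fold lower number from compound 2 to compound 4 (0.04 log units; that floor lies within the scatter), none beyond the scatter.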

Compound 4, half-maximal inhibitory concentration: 19200 nM
Beside the measured number, compound 4's estimate is 2.3-fold (0.37 log units) above it; the measured number falls inside the stated range.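

Compound 1 and compound 2 left this aromatic carbon unreadable, because both sit at the same limit: the limit of > 50000 nM in this assay, at which 2 of the 4 values shown sit. In this assay, among these compounds, formyl in place of methyl gives an at least 2.6-fold lower number from compound 2 to compound 4 (0.41 log units; beyond the scatter) and formyl in place of chloro gives an at least 2.6-fold lower number from compound 1 to compound 4 (0.41 log units; beyond the scatter) as the first readable change at this carbon. Each step starts from a limit, so only its minimum size is known. From the compounds shown here alone, how far the true size exceeds that minimum stays open. So does what an amine or a carboxylic acid on this aromatic carbon would give.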